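Second chloro on the shared core: expectation for compound 4

The compounds below may be only part of what the source reports. "The series", "measured", "known", "first", "only" and "open" are said of these compounds alone.

Compound 3 `C[C@H](NC(=O)Nc1ccccc1Cl)c1ccccc1` gives 106% in an ADME assay on the whole organism with Oryza sativa as the target, tested at 10 uM (on this read-out higher numbers stand for a weaker effect at the one concentration tested and lower numbers for a stronger effect), the highest number of the three, though compound 1 `C[C@H](NC(=O)Nc1ccccc1C(C)(C)C)c1ccccc1`, which gives 100%, sits within the scatter of it; the furthest is compound 2 `C[C@H](NC(=O)Nc1ccccc1F)c1ccccc1`, which gives 65%. The measured steps are a number 6 percentage points higher from compound 1 to compound 3 (within the scatter) and a number 41 percentage points higher from compound 2 to compound 3 (beyond the scatter). Compound 4 `C[C@H](NC(=O)Nc1cccc(Cl)c1Cl)c1ccccc1` differs from compound 3 by chloro in place of hydrogen on an aromatic carbon. Within the data shown here, no measured step exchanges hydrogen for chloro; the measured steps exchange one group for another on an aromatic carbon, and the only one ending at a chloro group, a number 6 percentage points higher from compound 1 to compound 3 (within the scatter), lies within the scatter. A step of a number 6 percentage points lower from compound 3 to compound 4 (within the scatter) is therefore expected, nothing beyond the scatter. Compound 4 is estimated at 100%, between 80% and 115%.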

Compound 4, a percentage reported as activity, at one concentration (the size of the read-out at that concentration, not a potency): 101%
Compound 4: middle estimate off by 1 percentage points, on the low side; low and high end bracket the measured number.
By their numbers in this assay, from the lowest: compound 2; then compounds 1, 4 and 3 (each within the scatter of the next).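

In this assay, among these compounds, the first exchange of hydrogen for chloro gives a number 5 percentage points lower from compound 3 to compound 4 (within the scatter), so a second chloro group ortho to a chloro group and meta to a large group leaves the read-out unchanged within the scatter. This position therefore tolerates added chlorine here, at least with the existing chloro group in place. Nothing available explains this result.

Going by these compounds, whether this position responds differently to a fluoro group, a methoxy group or an amine remains open. On these data alone, it is also open whether any such group would move the number beyond the scatter.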